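Swapping Methyl for Methoxy on Compound 1

The source may hold more compounds than are shown below. What is called first, only, known or untested is meant among the compounds shown, and "the series" means these compounds.

- compound 1 `Cc1ccc(C2=Nn3c(nnc3C(C)c3ccc(CC(C)C)cc3)SC2)cc1` gives 4000 nM
- compound 2 `CC(c1ccc(-c2ccccc2)c(F)c1)c1nnc2n1N=C(c1ccc(C(F)(F)F)cc1)CS2` gives 6100 nM

Both values come from a functional assay on HCT-116 cells (Homo sapiens) for inhibition, read by sulforhodamine B assay, with a stated time of 72 h (on this read-out higher numbers stand for weaker inhibition and lower numbers for stronger inhibition), and lie within the usual scatter of each other, so compound 1 cannot be ranked against compound 2. Compound 3 `COc1ccc(C2=Nn3c(nnc3C(C)c3ccc(CC(C)C)cc3)SC2)cc1` keeps the core of compound 1 and changes one group, 4-methylphenyl to 4-methoxyphenyl methoxy in place of methyl on an aromatic carbon with methoxy in place of methyl on an aromatic carbon. Within the data shown here, no measured pair shows this swap, so no shift beyond the scatter is expected in this assay here. The estimate means a 1.1-fold lower number from compound 1 to compound 3 (0.06 log units; within the scatter) as the expected step. For compound 3 the estimated value is 3500 nM within an expected range of 1500 nM to 8500 nM.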

Compound 3, half-maximal inhibitory concentration: 4200 nM
Compound 3: middle estimate off by 1.2-fold (0.08 log units), on the low side, and the stated range covers the measured number.
By their numbers in this assay, from the lowest: compounds 1, 3 and 2 (each within the scatter of the next).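

In this assay, exchanging the methyl for a methoxy, which adds an oxygen and a hydrogen-bond acceptor on the aromatic ring, gives a 1.1-fold higher number from compound 1 to compound 3 (0.02 log units; within the scatter), so the two compounds cannot be told apart. At this position, then, the first direct comparison shows that this swap leaves no readable mark on the number. Nothing on hand explains this result. As far as these compounds go, whether an amine, a carboxylic acid or a longer chain such as butoxy at this position would move the number stays open. So does whether the same swap would read alike with other groups elsewhere on the shared core.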